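This account rests on a few compounds, and the source may have more. Where it says the series, first, only, none or still open, it means among the compounds named here.

Measured so far, in a functional assay on aorta (Rattus norvegicus, strain Wistar) for inhibition, with a stated time of 60 min; on this read-out higher numbers stand for an effect only at larger amounts of compound and lower numbers for an effect already at smaller amounts:

- compound 1 `CCCOc1ccc(-c2nc3cc(C(F)(F)F)ccc3[nH]2)cc1`: compound 1 gives 524000 nM
- compound 2 `COc1cc(-c2nc3cc(C(F)(F)F)ccc3[nH]2)ccc1O`: compound 2 gives 140000 nM
- compound 3 `CCOc1ccccc1-c1nc2cc([N+](=O)[O-])ccc2[nH]1`: compound 3 gives 15000 nM

Compound 1 stands at the highest number of the three. Its nearest neighbour on the numbers is compound 2, which lies lower by a gap beyond the scatter; compound 3 lies lower still, by a much wider gap that is also beyond the scatter. None of these pairs differs in only one place, so the numbers are taken as they stand and no single change is read out of them.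

Compound 4 `CN(C)c1ccc(-c2nc3cc(C(F)(F)F)ccc3[nH]2)cc1` is not yet measured. It differs from compound 1 in one place: dimethylamino in place of propoxy on an aromatic carbon. For the measured compounds named here, no measured pair shows this change, and the other compounds change the core or the substitution pattern at the same time, so the expected step is not anchored. A modest shift toward a lower number is expected for compound 4, a 1.7-fold lower number from compound 1 to compound 4 (0.24 log units; within the scatter), but a result within the scatter of compound 1 would not surprise. The estimate for compound 4 is 300000 nM, with a range from 80000 nM to 1000000 nM.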

Compound 4, half-maximal effective concentration: 550000 nM
Beside the measured number, compound 4's estimate is 1.8-fold (0.26 log units) below it; measured number inside the range.
By their numbers in this assay, from the lowest: compound 3; then compound 2; then compounds 1 and 4 (each within the scatter of the next).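

In this assay, for the compounds shown here, the step from propoxy to dimethylamino on an aromatic carbon, para to a large group, gives a 1.0-fold higher number from compound 1 to compound 4 (0.02 log units; within the scatter) and is the first one-place comparison. At this position, propoxy with its 4 heavy atoms and dimethylamino with its 3 heavy atoms cannot be told apart on this read-out, although oxygen gives way to nitrogen and the chain is replaced by a branched group; the pair therefore offers no handle on the number at this place. No measured property of either group accompanies this result, and nothing bears on how the two compare beyond the read-out itself.

Going by these compounds, it remains open whether this flat step extends to groups of a different kind at the same place, such as a primary amine, a carboxylic acid or a longer chain such as hexyloxy. On these data alone, it is equally open whether the same exchange would behave alike with a nitro group in place of trifluoromethyl on the shared core, or with the substituent placed elsewhere on the aromatic ring.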